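The source may hold more compounds than are shown below. What is called first, only, known or untested is meant among the compounds shown, and "the series" means these compounds.

In a functional assay on cells (Homo sapiens) for inhibition, read by MTT assay, with a stated time of 48 h (on this read-out lower numbers stand for stronger inhibition and higher numbers for weaker inhibition), three compounds have been measured so far, and a fourth is still to come.

compound 1 `O=C(CCCCOc1no[n+]([O-])c1S(=O)(=O)c1ccccc1)NO` gives 4300 nM
compound 2 `CC(C)(COc1no[n+]([O-])c1S(=O)(=O)c1ccccc1)C(=O)NO` gives 18300 nM
compound 3 `O=C(/C=C/COc1no[n+]([O-])c1S(=O)(=O)c1ccccc1)NO` gives 57700 nM

Compound 1 holds the lowest number of the three, and its steps to both others lie beyond the scatter. Compound 4 `O=C(NO)OCCOCCOc1no[n+]([O-])c1S(=O)(=O)c1ccccc1` keeps the core of compound 1 but alters the chain (2-((hydroxycarbamoyl)oxy)ethoxy in place of 2-(hydroxycarbamoyl)ethyl on a saturated chain carbon, two bonds along the chain from an oxygen on an aromatic ring), with 2-((hydroxycarbamoyl)oxy)ethoxy in place of 2-(hydroxycarbamoyl)ethyl. Two measured steps also alter this chain. The first is modest (a 4.3-fold higher number from compound 1 to compound 2 (0.63 log units; beyond the scatter)) and the second is large (a 13-fold higher number from compound 1 to compound 3 (1.13 log units; beyond the scatter)), and both raise the number. Neither introduces the new group, so they offer only indirect guidance. With just compound 2 and compound 3 to go on, a modest rise is expected in this assay rather than a gain. The expected change is small to moderate (a 2.6-fold higher number from compound 1 to compound 4 (0.41 log units; beyond the scatter)). For compound 4 the estimate is 11000 nM, with an expected range from 3500 nM to 35000 nM.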

Compound 4, half-maximal inhibitory concentration: 19400 nM
The estimate for compound 4 lay 1.8-fold (0.25 log units) below the measured number, and the stated range covers the measured number.
By their numbers in this assay, from the lowest: compound 1; then compounds 2 and 4 (each within the scatter of the next); then compound 3.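

In this assay the swap of 2-(hydroxycarbamoyl)ethyl for 2-((hydroxycarbamoyl)oxy)ethoxy gives a 4.5-fold higher number from compound 1 to compound 4 (0.65 log units; beyond the scatter), so a larger chain with more oxygen atoms also raises the number at this position, as the branched and unsaturated chains of compound 2 and compound 3 did. All three chain changes shown therefore raise the number from compound 1, and compound 4 lies within the scatter of compound 2 despite the different alteration. Nothing at hand accounts for the rise seen with compound 4.

This single step changes chain length and oxygen content together, so the compounds shown cannot separate the two. Going by these compounds, it remains open how a longer all-carbon chain ending in hydroxycarbamoyl would read here, or whether a carboxylic acid in place of hydroxycarbamoyl would keep any of the inhibition.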